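The source may hold more compounds than are shown below. What is called first, only, known or untested is meant among the compounds shown, and "the series" means these compounds.

Within the data shown here, compound 1 `COc1ccc2nc(C)cc(OCC(=O)Nc3ccc4c(c3)CCC4)c2c1` holds the higher of the two numbers so far: in a physicochemical assay for solubility, read by HPLC, measured as thermodynamic solubility, with a stated time of 24 h, at pH 4 (a higher number here means a more soluble compound, a lower number a less soluble compound), compound 1 gives 120000 nM, and compound 2 `COc1ccc2nc(C)cc(OCC(=O)Nc3ccc4c(c3)CCCC4)c2c1` gives 30000 nM in this assay. Compound 3 `CCc1ccc(NC(=O)COc2cc(C)nc3ccc(OC)cc23)cc1` has not yet been measured. Relative to compound 1 the change is 4-ethylphenyl in place of 2,3-dihydro-1H-inden-5-yl on an amide-type nitrogen. Among the measured compounds shown here, nothing measured so far bears directly on this exchange, so only a small step in this assay is expected, close to the scatter, if anything upward. Compound 3 is therefore expected to give about 150000 nM in this assay, within 50000 nM to 400000 nM, an estimated step of a 1.3-fold higher number from compound 1 to compound 3 (0.10 log units; within the scatter).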

Compound 3, solubility: 430000 nM
For compound 3 the middle estimate is 2.9-fold (0.46 log units) below the measured one; measured number above the stated range.
By their numbers in this assay, from the lowest: compound 2; then compound 1; then compound 3.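

In this assay, 4-ethylphenyl in place of 2,3-dihydro-1H-inden-5-yl on an amide-type nitrogen gives a 3.6-fold higher number from compound 1 to compound 3 (0.55 log units; beyond the scatter) with the rest of the molecule unchanged. This position therefore moves the number beyond the scatter, even though the exchange removes only the five-membered non-aromatic ring and one carbon, with no hydrogen-bond donors or acceptors and no net charge on either group. Nothing available explains this step.
From the compounds shown here alone, it remains open whether the ethyl chain or the loss of the fused ring matters more. A longer chain such as 4-propylphenyl, or a phenyl carrying an amine or a carboxylic acid, is untested among the compounds shown.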